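The source may report more compounds than this note shows. Statements on the series, on what has been measured and on what is new or still open speak of the compounds shown alone.

Working notes on the aryl group of the shared core.

Three compounds share the core of compound 1 `N#Cc1ccc(-c2nc(C(c3ccc(F)cc3)c3ccc(F)cc3)sc2CC(=O)O)cc1` and differ only in the aryl group on the thiazole carbon. In an in vitro assay on HEK385-7 cells for displacement of a labelled ligand from prostaglandin D2 receptor 2 (Homo sapiens) (on this read-out lower numbers stand for stronger inhibition and higher numbers for weaker inhibition), compound 1 gives 150 nM. Compound 2 `O=C(O)Cc1sc(C(c2ccc(F)cc2)c2ccc(F)cc2)nc1-c1ccoc1` gives 14 nM in this assay, and compound 3 `Cc1cc(-c2nc(C(c3ccc(F)cc3)c3ccc(F)cc3)sc2CC(=O)O)ccn1` gives 3.1 nM. Compound 3 stands lowest of the three: the step of a 48-fold lower number from compound 1 to compound 3 (1.68 log units; beyond the scatter) is large, and a 4.5-fold lower number from compound 2 to compound 3 (0.65 log units; beyond the scatter) is modest; the remaining step of an 11-fold lower number from compound 1 to compound 2 (1.03 log units; beyond the scatter) is also large. All three steps sit at the same position, so this assay responds strongly to the aryl group here.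

Compound 4 `Nc1cc(-c2nc(C(c3ccc(F)cc3)c3ccc(F)cc3)sc2CC(=O)O)cc(F)n1` keeps the pyridine of compound 3 and changes its substituents: 2-amino-6-fluoropyridin-4-yl in place of 2-methylpyridin-4-yl on an aromatic carbon. Among the measured compounds shown here, no measured step exchanges substituents on a pyridine, so the three steps bear only indirectly, showing that this position can move the number a lot in either direction. A small step is expected for compound 4, a 1.5-fold higher number from compound 3 to compound 4 (0.16 log units; within the scatter), with wide uncertainty. Compound 4 is estimated at 4.5 nM in this assay, within 1.5 nM to 18 nM.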

Compound 4, half-maximal inhibitory concentration: 220 nM
The estimate for compound 4 lay 49-fold (1.69 log units) below the measured number; measured number above the stated range.
By their numbers in this assay, from the lowest: compound 3; then compound 2; then compounds 1 and 4 (each within the scatter of the next).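

Substituents on the pyridine can matter as much as the choice of aryl ring: in this assay, with the ring kept as a pyridine, a 71-fold higher number from compound 3 to compound 4 (1.85 log units; beyond the scatter) is the largest step yet seen at this position. A pyridine at this position therefore does not by itself bring a low number, as a 16-fold higher number from compound 2 to compound 4 (1.20 log units; beyond the scatter) puts the 2-amino-6-fluoropyridin-4-yl compound well behind the furan-3-yl one. It also sits level with the 4-cyanophenyl compound, with a 1.5-fold higher number from compound 1 to compound 4 (0.17 log units; within the scatter). No supporting data on this loss are available.

The compounds shown leave open whether the amino group, the fluorine or their combination carries the step, since both enter together and the methyl leaves at the same time. A 2-aminopyridin-4-yl group and a 2-fluoro-6-methylpyridin-4-yl group would separate these contributions.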